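This account rests on a few compounds, and the source may have more. Where it says the series, first, only, none or still open, it means among the compounds named here.

Measured in a functional assay on the whole organism for antagonist activity, with Mus musculus as the target; a higher number here means that more compound is needed for the effect, a lower number that less compound is needed:
- Compound 1 `CCC(=O)N(c1ccc(OC)cc1)C1CCCC1N(C)C`: 20 mg/kg; 20 mg/kg (2 entries)
- Compound 2 `CCC(=O)N(c1ccc(F)cc1)C1CCCC1N(C)C`: 0.08 mg/kg
- Compound 3 `CCC(=O)N(c1ccc(F)c(Cl)c1)C1CCCC1N(C)C`: 2 mg/kg

Compound 2 has the lowest number of these three, so little compound is needed for the effect. Compound 4 `CCC(=O)N(c1ccc(C(F)(F)F)cc1)C1CCCC1N(C)C`, not yet measured, has trifluoromethyl in place of fluoro on an aromatic carbon of compound 2: trifluoromethyl in place of fluoro on an aromatic carbon.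

Two results bear on this change. Chloro in place of hydrogen on an aromatic carbon gave a large rise: a 25-fold higher number from compound 2 to compound 3 (1.40 log units; beyond the scatter). Compound 1, with a different group at the place of the fluoro, reads 20 mg/kg; 20 mg/kg (2 entries). Neither is a direct precedent, but both suggest a sizeable rise in this assay.

The expected change is a 13-fold higher number from compound 2 to compound 4 (1.10 log units; beyond the scatter). For compound 4 the estimate is 1 mg/kg, with an expected range of 0.2 mg/kg to 6 mg/kg.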

Compound 4, dose for half-maximal effect: 25 mg/kg
Compound 4: the middle estimate sits 25-fold (1.40 log units) below what was measured; measured number outside the range, above it.
By their numbers in this assay, from the lowest: compound 2; then compound 3; then compound 4.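

In this assay, trifluoromethyl in place of fluoro gives a 310-fold higher number from compound 2 to compound 4 (2.49 log units; beyond the scatter), a far larger step than the chloro addition gave, a 25-fold higher number from compound 2 to compound 3 (1.40 log units; beyond the scatter). Two different groups at this position now read alike: compound 1 with methoxy gives 20 mg/kg; 20 mg/kg (2 entries) and compound 4 gives 25 mg/kg, values within the usual scatter of each other, and both are far above the value of compound 2. Nothing measured here explains why this swap has so large an effect.

Open, from the compounds shown here alone, is how hydrogen, chloro alone, methyl or an amine at this position would read, and so whether fluoro is unusual here or whether other small groups serve as well.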